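The source may report more compounds than this note shows. Statements on the series, on what has been measured and on what is new or still open speak of the compounds shown alone.

Measured compounds:
compound 1 `Cc1nn(-c2ccccc2)c2nc(C(=O)N3NC(=O)/C(=C/c4ccccc4)N=C3c3ccccc3)[nH]c(=O)c12`, 120 nM
compound 2 `Cc1nn(-c2ccccc2)c2nc(C(=O)N3NC(=O)/C(=C/c4ccccc4)N=C3c3ccc(Cl)cc3)[nH]c(=O)c12`, 12.3 nM

In a functional assay on MCF7 cells (Homo sapiens) for cytotoxicity, read by MTT assay, with a stated time of 48 h (on this read-out higher numbers stand for weaker inhibition and lower numbers for stronger inhibition), compound 2 gives the lower of the two numbers recorded, and its nearest neighbour is compound 1, which gives 120 nM. Among the measured compounds shown here, the gap between them is the single step known so far, a 9.8-fold lower number from compound 1 to compound 2 (0.99 log units; beyond the scatter), and that step lies beyond the scatter.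

Compound 3 `Cc1ccc(C2=N/C(=C\c3ccccc3)C(=O)NN2C(=O)c2nc3c(c(C)nn3-c3ccccc3)c(=O)[nH]2)cc1` has not yet been measured. It differs from compound 2 in one place: methyl in place of chloro on an aromatic carbon. For the measured compounds named here, no measured step in this assay involves a methyl group, so the only step that bears on this change is the one from hydrogen to chloro at the same place, a 9.8-fold lower number from compound 1 to compound 2 (0.99 log units; beyond the scatter). That step shows the unsubstituted ring of compound 1 to be the weaker partner, but it says nothing direct about how a methyl compares with a chloro there.

On this basis compound 3 is expected to give a number lying between those of compound 1 and compound 2, with a 2.0-fold higher number from compound 2 to compound 3 (0.31 log units; beyond the scatter) as the estimated step, and an estimate of 25 nM, within 8 nM to 80 nM.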

Compound 3, half-maximal inhibitory concentration: 127 nM
Compound 3: the middle estimate sits 5.1-fold (0.71 log units) below what was measured; measured number above the stated range.
By their numbers in this assay, from the lowest: compound 2; then compounds 1 and 3 (each within the scatter of the next).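

In this assay the drop seen with chloro does not extend to methyl on the same carbon, para to a large group: there is a 10-fold higher number from compound 2 to compound 3 (1.01 log units; beyond the scatter), a large step for the exchange of one heavy atom for another. Set against the hydrogen, the methyl brings no change, with a 1.1-fold higher number from compound 1 to compound 3 (0.02 log units; within the scatter), which lies within the scatter, so the mere presence of a substituent at this place does not go with the lower number, and among these three compounds only the chloro of compound 2 stands apart. The position is therefore sensitive to which group it carries, yet nothing offered here, whether a measured property of these groups or any other finding, accounts for the gap between chloro and methyl.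

The compounds shown leave open whether the lower number belongs to chloro alone or would also appear with fluoro, bromo, methoxy, an amine or a nitrile at this place. They also leave open whether chloro would have the same effect on other carbons of this ring, or in a core changed elsewhere.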